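A Vinyl Group Added to the Shared Core

The source may report more compounds than this note shows. Statements on the series, on what has been measured and on what is new or still open speak of the compounds shown alone.

Compound 1 `O=C1C=C(CO)[C@H](O)[C@H]2O[C@@H]12` is the unsubstituted core. In a functional assay on SKW 6.4 cells (Homo sapiens) for cytotoxicity (on this read-out higher numbers stand for weaker inhibition and lower numbers for stronger inhibition), compound 1 gives > 80000 nM, which is a limit of this assay and not a number; its value sits at the limit of > 80000 nM in this assay, at which 1 of the 2 values shown sits. Compound 2 `CCCC/C=C/C1=C(CO)[C@H](O)[C@H]2O[C@H]2C1=O` gives 35000 nM in this assay. Compound 3 `C=CC1=C(CO)[C@H](O)[C@H]2O[C@H]2C1=O` carries vinyl in place of hydrogen on a double-bonded ring carbon. Compound 3 is expected to fall near 50000 nM, within 20000 nM to 80000 nM, because compound 2 gives 35000 nM in this assay. The estimated step of an at least 1.6-fold lower number from compound 1 to compound 3 (0.20 log units; that floor lies within the scatter) is expected to be modest, toward stronger inhibition, and may stay within the scatter.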

Compound 3, half-maximal inhibitory concentration: > 80000 nM
Compound 3 ended at the assay's limit; the forecaster's own chance of this, stated with the estimate: 35%; at least 1.6-fold (0.20 log units) between middle value and limit.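

Compound 1 and compound 3 both end at a limit and not at a number, so the step between them cannot be read in this assay: the limit of > 80000 nM in this assay, at which 2 of the 3 values shown sit. The compounds shown leave open whether vinyl in place of hydrogen changes the value at all.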